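The compounds below may be only part of what the source reports. "The series", "measured", "known", "first", "only" and "open" are said of these compounds alone.

Compound 2, `CCOC(=O)/C(=C/c1ccccc1)CN1C(=O)[C@@H](OC)[C@H]1c1ccc(F)cc1`, is the ethyl ester of the series. In an ADME assay on cells (Epithelial cell, Homo sapiens) for antiproliferative activity, read by MTT assay, with a stated time of 48 h (on this read-out lower numbers stand for stronger inhibition and higher numbers for weaker inhibition), compound 2 gives "not toxic" (no number reported), so there is no number for it, only the report that it showed no toxicity at the concentrations tested. Compound 4, `COC(=O)/C(=C/c1ccccc1)CN1C(=O)[C@@H](OC)[C@H]1c1ccc(F)cc1`, differs from compound 2 by hydrogen in place of methyl on a saturated chain carbon bound to an oxygen next to a carbonyl group. Going by the values given here, no measured step follows this same change, so the only anchors are the two methyl esters that do carry numbers. Compound 1, `COC(=O)/C(=C/c1ccccc1)CN1C(=O)[C@@H](OC)[C@H]1c1ccc(Cl)cc1`, gives 37900 nM in this assay, and compound 3, `COC(=O)/C(=C/c1ccccc1)CN1C(=O)[C@@H](OC)[C@H]1c1cccc(C(F)(F)F)c1`, gives 71800 nM in this assay; the step of a 1.9-fold higher number from compound 1 to compound 3 (0.28 log units; within the scatter) concerns the aryl group, not the ester, and lies within the scatter. Compound 4 shares the methyl ester of compound 1 and compound 3, so its value is expected to sit in the same weak range, if it is measurable at all rather than again reported without a number. The estimate for compound 4 in this assay is 50000 nM, with a range from 20000 nM to 150000 nM.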

Compound 4, half-maximal inhibitory concentration: 27900 nM
Estimate against measurement, compound 4: 1.8-fold (0.25 log units) above, within the range that was stated.
By their numbers in this assay, from the lowest: compounds 4, 1 and 3 (each within the scatter of the next, the first and the last beyond it).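

In this assay compound 4 gives 27900 nM while compound 2, its ethyl ester counterpart, carries only the report "not toxic", so the ethyl to methyl change separates a number from no number, but this step itself cannot be read. Going by these compounds alone, on the aryl group, fluoro in place of chloro gives a 1.4-fold lower number from compound 1 to compound 4 (0.13 log units; within the scatter) and 4-fluorophenyl in place of 3-(trifluoromethyl)phenyl gives a 2.6-fold lower number from compound 3 to compound 4 (0.41 log units; beyond the scatter), the only modest step in the set. No evidence is available that would explain either result.

On these data alone, it remains open how a propyl ester or a carboxylic acid in place of the methyl ester of compound 4 would read in this assay. As far as these compounds go, it also remains open whether an actual number exists for compound 2.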